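From hex-5-yn-1-yl to methyl on the oxygen

A few compounds are considered here, and "the series" means these few. Any claim that something is new, unique, unknown or untested is made for them only; others in the source may bear on it.

In a functional assay on MCF7 cells (Homo sapiens) for inhibition, read by colorimetric assay and MTT assay, with a stated time of 72 h (on this read-out lower numbers stand for stronger inhibition and higher numbers for weaker inhibition), compound 1 `CCCCOc1ncc(-c2ccccc2OC)n1C` gives 55000 nM. Within the data shown here, compound 2 `C#CCCCCOc1ncc(-c2ccccc2OC)n1C` gives 10000 nM, the lower of the two numbers measured so far. Among the measured compounds shown here, only one measured step bears on the next change: a 5.5-fold lower number from compound 1 to compound 2 (0.74 log units; beyond the scatter). That step is modest, and it comes with ethynyl in place of hydrogen on a saturated chain carbon.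

Compound 3 `COc1ccccc1-c1cnc(OC)n1C` has not yet been measured in this assay. The difference is hydrogen in place of pent-4-yn-1-yl on a saturated chain carbon bound to an oxygen on an aromatic ring, or hex-5-yn-1-yl to methyl when cut one bond further out. For the measured compounds named here, this change removes the ethynyl and more of the chain, and no measured compound carries a group this small, so the guide is only partial. Compound 1 also lacks the ethynyl and sits at 55000 nM, which points to a higher number. The expected step is a 5.0-fold higher number from compound 2 to compound 3 (0.70 log units; beyond the scatter). For compound 3 the estimated value is 50000 nM, with an expected range of 15000 nM to 150000 nM.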

Compound 3, half-maximal inhibitory concentration: > 100000 nM
Compound 3: only a limit was reported (the forecaster's own chance of this, stated with the estimate: 25%); middle value at least 2.0-fold (0.30 log units) away from the limit.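

The reading for compound 3 in this assay is a limit of the assay and not a number: the limit of > 100000 nM in this assay, at which 1 of the 3 values shown sits.

Cutting hex-5-yn-1-yl back to methyl on the oxygen gives an at least 10-fold higher number from compound 2 to compound 3 (1.00 log units; beyond the scatter), which shows that this position does not keep the lower number of compound 2 once the whole chain and its ethynyl are gone. The comparison with the saturated chain is less firm, at an at least 1.8-fold higher number from compound 1 to compound 3 (0.25 log units; that floor lies within the scatter): that floor lies within the scatter, so the limit alone does not show that methyl is worse than the chain of compound 1, and only the size of the step from compound 2 is secure.

The compounds shown do not separate the contribution of the ethynyl from that of chain length, since compound 2 differs from compound 1 at the chain end and compound 3 loses both features at once; a saturated hexyl chain or a shorter propargyl group on the oxygen would bear on this directly. Also open, as far as these compounds go, is whether the chain end must be an ethynyl at all, or whether an amine or a carboxylic acid there would give a comparable number.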